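The compounds below may be only part of what the source reports. "The series", "measured", "known", "first", "only" and "open" are said of these compounds alone.

Measured compounds in a functional assay (Cavia porcellus) with sulfonylurea receptors; K-ATP channels (Homo sapiens) as the target; a higher number here means a weaker inhibitor, a lower number a stronger inhibitor:
compound 1 `CC(O)(C(=O)Nc1ccc(C#N)c(S(=O)(=O)c2ccccc2)c1)C(F)(F)F` gives 2600 nM.
compound 2 `CC(O)(C(=O)Nc1ccc(C#N)c(Sc2ccccc2)c1)C(F)(F)F` gives 8300 nM.
compound 3 `CC(O)(C(=O)Nc1ccc(S(=O)(=O)c2ccccc2C#N)cc1)C(F)(F)F` gives 1100 nM.

Compound 3 has the lowest number of the three in this assay; its steps to compound 1 and to compound 2 are both beyond the scatter, so it is the strongest inhibitor of the measured set. Compound 4 `CC(O)(C(=O)Nc1ccc(S(=O)(=O)c2ccccc2Cl)cc1)C(F)(F)F` is not yet measured. It differs from compound 3 by chloro in place of cyano on an aromatic carbon, on the pendant ring, ortho to a large group. Within the data shown here, the only measured step, a 3.2-fold higher number from compound 1 to compound 2 (0.50 log units; beyond the scatter), concerns the linker and not this ring; no measured pair exchanges cyano for chloro. With nothing comparable to rest on, compound 4 is estimated to sit near compound 3, the step of a 1.4-fold higher number from compound 3 to compound 4 (0.13 log units; within the scatter) expected within the scatter. Compound 4 is estimated at 1500 nM, range 600 nM to 4000 nM.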

Compound 4, half-maximal inhibitory concentration: 2300 nM
Estimate against measurement, compound 4: 1.5-fold (0.19 log units) below, and the stated range covers the measured number.
By their numbers in this assay, from the lowest: compound 3; then compounds 4 and 1 (each within the scatter of the next); then compound 2.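

In this assay, among these compounds, the change from 2-cyanophenyl to 2-chlorophenyl gives a 2.1-fold higher number from compound 3 to compound 4 (0.32 log units; beyond the scatter), the first measured step on the pendant ring. The number at this position, ortho to a large group, therefore depends on the substituent, and of the two groups cyano gives the lower number. No measured evidence on hand bears on the origin of this step.

The compounds shown leave open how an amine, a methoxy group or plain hydrogen at this position would compare with cyano and chloro. From the compounds shown here alone, whether the same exchange gives a similar step with a phenylsulfanyl linker also remains open.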